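This account rests on a few compounds, and the source may have more. Where it says the series, first, only, none or still open, it means among the compounds named here.

Measured so far:
compound 1 `CC(C)CC1OCCC(Cl)=C1[Si](C)(C)C` — 28000 nM in a functional assay on SW1573 cells (Homo sapiens) for antiproliferative activity; a higher number here means a weaker inhibitor of growth, a lower number a stronger inhibitor of growth
compound 2 `C[C@H]1CC(Cl)=C([Si](C)(C)C)[C@@H](C2CCCCC2)O1` — 31000 nM in this assay

Compound 2 and compound 1 sit within the usual scatter of each other in this assay, so neither stands apart from the other on what has been measured; both lie far up the concentration range. Compound 3 `C[C@H]1CC(Cl)=C[C@@H](C2CCCCC2)O1` differs from compound 2 in one place: a hydrogen atom in place of a group of 4 heavy atoms (3 carbon, 1 silicon; no ring), on a double-bonded ring carbon. For the measured compounds named here, no measured pair in this set shows the effect of such a change, so there is nothing to scale an expectation against. Compound 3 is therefore expected to give at most a modest step in this assay, a 1.2-fold higher number from compound 2 to compound 3 (0.09 log units; within the scatter), leaning if anything towards a weaker inhibition of growth. For compound 3 the estimate in this assay is 38000 nM, with a range from 12000 nM to 120000 nM.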

Compound 3, concentration for total growth inhibition: 43000 nM
Estimate against measurement, compound 3: 1.1-fold (0.05 log units) below; measured number inside the range.
By their numbers in this assay, from the lowest: compounds 1, 2 and 3 (each within the scatter of the next).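

For the compounds shown here, compound 3 gives the first direct reading at this position: in this assay, a hydrogen atom in place of the group of 4 heavy atoms (3 carbon, 1 silicon; no ring) on the double-bonded ring carbon gives a 1.4-fold higher number from compound 2 to compound 3 (0.14 log units; within the scatter) and so does not separate the two compounds. In this pair, then, activity in this assay does not depend on that group being present, and the number stays far up the concentration range without it. Nothing available explains this result.

On these data alone, whether an amine, a carboxylic acid or a longer chain on this ring carbon would move the number beyond the scatter stays open. So does whether the same exchange would behave alike on the core of compound 1, since this is a single pair.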